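Ring oxygen introduced into the carbamate substituent

The source may report more compounds than this note shows. Statements on the series, on what has been measured and on what is new or still open speak of the compounds shown alone.

Measured so far:
compound 1 `CCC1(OC(=O)N2CCC(Oc3ncnc(Oc4ccc(S(C)(=O)=O)nc4C)c3F)CC2)CC1`: 333 nM
compound 2 `Cc1nc(S(C)(=O)=O)ccc1Oc1ncnc(OC2CCN(C(=O)OC3(C(F)(F)F)CCC3)CC2)c1F`: 63.3 nM

Within the data shown here, in a functional assay on isolated protein for inhibition of Glucose-dependent insulinotropic receptor (Rattus norvegicus), read by HTRF and cAMP accumulation (a higher number here means that more compound is needed for the effect, a lower number that less compound is needed), compound 2 gives 63.3 nM, the lower of the two numbers; the only measured step, a 5.3-fold lower number from compound 1 to compound 2 (0.72 log units; beyond the scatter), is a modest one and separates it from compound 1. Compound 3 `Cc1nc(S(C)(=O)=O)ccc1Oc1ncnc(OC2CCN(C(=O)OC3(C(F)(F)F)COC3)CC2)c1F` differs from compound 2 in one place: 3-(trifluoromethyl)oxetan-3-yl in place of 1-(trifluoromethyl)cyclobutyl on an oxygen next to a carbonyl group. Among the measured compounds shown here, no measured step addresses a ring oxygen in this substituent, so the change from compound 2 to compound 3 is expected to lie within the scatter, with the estimated step being a 1.3-fold higher number from compound 2 to compound 3 (0.10 log units; within the scatter). For compound 3 the expected value in this assay is 80 nM, with a range of 30 nM to 250 nM.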

Compound 3, half-maximal effective concentration: 342 nM
Beside the measured number, compound 3's estimate is 4.3-fold (0.63 log units) below it; the whole stated range lies below it.
By their numbers in this assay, from the lowest: compound 2; then compounds 1 and 3 (each within the scatter of the next).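

In this assay, 3-(trifluoromethyl)oxetan-3-yl in place of 1-(trifluoromethyl)cyclobutyl on an oxygen next to a carbonyl group gives a 5.4-fold higher number from compound 2 to compound 3 (0.73 log units; beyond the scatter), so a single ring atom changes the result at this position. Against 1-ethylcyclopropyl, the same group gives a 1.0-fold higher number from compound 1 to compound 3 (0.01 log units; within the scatter), so a trifluoromethyl group on a four-membered ring does not by itself give the low number of compound 2. No available evidence accounts for this difference.

Open, going by these compounds, is whether the effect belongs to the ring oxygen specifically. A ring nitrogen as an amine, or a ring sulfur, at the same ring place could test this.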